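From Phenyl to 3,4-Difluorophenyl on the Amide Nitrogen

The source may hold more compounds than are shown below. What is called first, only, known or untested is meant among the compounds shown, and "the series" means these compounds.

Measured so far:
compound 1, `O=C(O)CCc1ccc(OCc2nnc(C(=O)Nc3ccccc3)s2)cc1`: 1060 nM
compound 2, `O=C(O)CCc1ccc(OCc2nnc(C(=O)Nc3ccc(F)cc3)s2)cc1`: 6640 nM
compound 3, `COc1cccc(NC(=O)c2nnc(COc3ccc(CCC(=O)O)cc3)s2)c1`: 4680 nM

Three compounds share one core and differ only in the ring attached to the amide-type nitrogen. In a functional assay on CHO cells for agonist activity at Free fatty acid receptor 1 (Homo sapiens), read by calcium flux (on this read-out lower numbers stand for an effect already at smaller amounts and higher numbers for an effect only at larger amounts of compound), compound 1 gives 1060 nM, the lowest of the three numbers; compound 3 stands nearest, a 4.4-fold higher number from compound 1 to compound 3 (0.64 log units; beyond the scatter), and compound 2 furthest, a 6.3-fold higher number from compound 1 to compound 2 (0.80 log units; beyond the scatter). Compounds 2 and 3 lie within the scatter of each other: a 1.4-fold lower number from compound 2 to compound 3 (0.15 log units; within the scatter).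

Compound 4, `O=C(O)CCc1ccc(OCc2nnc(C(=O)Nc3ccc(F)c(F)c3)s2)cc1`, has not yet been measured. Its change from compound 1 is 3,4-difluorophenyl in place of phenyl on an amide-type nitrogen. The step that bears on it most is a 6.3-fold higher number from compound 1 to compound 2 (0.80 log units; beyond the scatter), where one fluoro in place of hydrogen on an aromatic carbon moved the number beyond the scatter; the step of a 4.4-fold higher number from compound 1 to compound 3 (0.64 log units; beyond the scatter), with methoxy in place of hydrogen on an aromatic carbon, moved it the same way. With a second fluorine now added, a higher number is expected, at least as large as that of compound 2. Compound 4 is therefore estimated to give 7500 nM in this assay, within 2500 nM to 22000 nM, an expected 7.1-fold higher number from compound 1 to compound 4 (0.85 log units; beyond the scatter).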

Compound 4, half-maximal effective concentration: 580 nM
Compound 4: middle estimate off by 13-fold (1.11 log units), on the high side; the whole stated range lies above it.
By their numbers in this assay, from the lowest: compounds 4 and 1 (each within the scatter of the next); then compounds 3 and 2 (each within the scatter of the next).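

In this assay, a second fluoro on the ring of compound 2 does not push the number further the same way but brings it back, an 11-fold lower number from compound 2 to compound 4 (1.06 log units; beyond the scatter), so the effect of a fluoro at this position depends on what else the ring carries, and single changes here do not simply add up. Against the plain phenyl the 3,4-difluorophenyl ring shows a 1.8-fold lower number from compound 1 to compound 4 (0.26 log units; within the scatter), and against the 3-methoxyphenyl ring it shows an 8.1-fold lower number from compound 3 to compound 4 (0.91 log units; beyond the scatter), so a substituted ring on the amide-type nitrogen does not always mean a higher number, as compounds 2 and 3 alone had suggested. Nothing at hand gives a reason for this turn.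

Going by these compounds, it remains open whether a ring carrying two chloro groups or a nitrile would fall with compound 4 or with compounds 2 and 3. Also open, on these data alone, is what a methyl group in place of the amide hydrogen would do.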